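This account rests on a few compounds, and the source may have more. Where it says the series, first, only, none or still open, it means among the compounds named here.

Measured compounds:
compound 1 `COc1ccc(-c2nnc(-c3cc([N+](=O)[O-])cn3C)o2)cc1`, 281000 nM
compound 2 `O=[N+]([O-])c1c[nH]c(-c2nnc(Cc3ccc(F)c4ccccc34)o2)c1`, 229000 nM
compound 3 `Cn1cc([N+](=O)[O-])cc1-c1nnc(Cc2ccccc2F)o1`, 245000 nM

In an ADME assay on Vero cells (Chlorocebus sabaeus) for cytotoxicity, read by MTT assay, with a stated time of 72 h (on this read-out higher numbers stand for weaker inhibition and lower numbers for stronger inhibition), compound 1 gives 281000 nM. Compound 3 gives 245000 nM and compound 2 gives 229000 nM. All three numbers lie within the scatter of one another, so compound 1 is not set apart from compound 2 or compound 3 on this read-out. For the measured compounds named here, no pair of measured compounds differs in only one place, so the series supplies no measured step to lean on.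

Compound 4 `Cn1cc([N+](=O)[O-])cc1-c1nnc(-c2ccc(C#N)cc2)o1` has not yet been measured. It differs from compound 1 as follows: cyano in place of methoxy on an aromatic carbon. The three measured compounds carry differing substituents and linkers yet return close numbers, so for this change no step beyond the scatter is expected in this assay, and no direction can be read from the data. Compound 4 is expected to give 250000 nM, in the range 120000 nM to 500000 nM. This estimate means an expected step of a 1.1-fold lower number from compound 1 to compound 4 (0.05 log units; within the scatter), judged to be none beyond the scatter.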

Compound 4, half-maximal inhibitory concentration: 315000 nM
Compound 4: middle estimate off by 1.3-fold (0.10 log units), on the low side, within the range that was stated.
By their numbers in this assay, from the lowest: compounds 2, 3, 1 and 4 (each within the scatter of the next).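

In this assay, the series now has its first pair differing in one place: cyano in place of methoxy on an aromatic carbon, para to a large group, gives a 1.1-fold higher number from compound 1 to compound 4 (0.05 log units; within the scatter) and so stays within the scatter. The earlier compounds shown here differ in more than one place and could only show close numbers across mixed structures, whereas this pair isolates a single exchange at this position and shows no step that can be told from the scatter. No measurement at hand gives a reason for this result.

Open, as far as these compounds go, is whether an amine or a carboxylic acid at this same position would also stay within the scatter. Also open, from the compounds shown here alone, is whether cyano in place of methoxy would give a similar step on a compound with a methylene linker, such as compound 3.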